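The source may hold more compounds than are shown below. What is called first, only, known or untested is meant among the compounds shown, and "the series" means these compounds.

Measured in an assay on IMR-32 cells for inhibition of Voltage-dependent N-type calcium channel subunit alpha-1B (Homo sapiens); a higher number here means a weaker inhibitor, a lower number a stronger inhibitor:

Compound 1 `COc1ccc(COC(=O)[C@H](CSCC2CCCCC2)NC(=O)[C@@H]2CSCN2C(=O)OC(C)(C)C)cc1` gives 390 nM.
Compound 2 `COc1ccc(COC(=O)[C@@H](N)CSCC2CCCCC2)cc1` gives 5800 nM.
Compound 3 `CC(C)(C)OC(=O)N1CSC[C@H]1C(=O)N[C@@H](CSCC1CCCCC1)C(=O)NCc1ccc([N+](=O)[O-])cc1` gives 600 nM.

Among these three, compound 3 stands second highest. Its nearest neighbour is compound 1, and the change a 1.5-fold higher number from compound 1 to compound 3 (0.19 log units; within the scatter) lies within the scatter. Compound 2 stands furthest away, with a number clearly higher than compound 3.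

Compound 4 `CC(C)(C)OC(=O)N1CSC[C@H]1C(=O)N[C@@H](CSCC1CCCCC1)C(=O)NCc1ccc(OCc2ccccc2)cc1` differs from compound 3 in one place: benzyloxy in place of nitro on an aromatic carbon. Among the compounds with values here, no measured step touches this aromatic substituent alone; the only related step, from compound 1 to compound 3, also altered the link to the carbonyl and stayed within the scatter. In this assay the step of a 1.2-fold lower number from compound 3 to compound 4 (0.08 log units; within the scatter) is therefore expected to stay within the scatter. Compound 4 is estimated at 500 nM, with a range from 200 nM to 1500 nM.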

Compound 4, half-maximal inhibitory concentration: 500 nM
Compound 4: the middle estimate sits on the measured number at the digits printed; the measured number falls inside the stated range.
By their numbers in this assay, from the lowest: compounds 1, 4 and 3 (each within the scatter of the next); then compound 2.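

In this assay, benzyloxy in place of nitro on the aromatic carbon gives a 1.2-fold lower number from compound 3 to compound 4 (0.08 log units; within the scatter). This position therefore holds either a group of 8 heavy atoms with its own aromatic ring or one of 3 heavy atoms with no ring, and the number stays within the scatter. Nothing measured here bears on why the two groups read alike.

The compounds shown leave open whether an amine or a carboxylic acid on this aromatic carbon would also stay within the scatter. They also leave open how a plain hydrogen there would read.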